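The compounds below may be only part of what the source reports. "The series", "measured", "known", "first", "only" and "open" are said of these compounds alone.

Measured compounds in an ADME assay on MT4 cells (Homo sapiens) for cytotoxicity, read by MTT assay, with a stated time of 5 days; on this read-out lower numbers stand for higher toxicity in this test and higher numbers for lower toxicity in this test:
Compound 1 `Cc1cc(C#N)cc(C)c1Oc1nc(Nc2ccc(C#N)cc2)ncc1-c1ccccc1`: compound 1 gives 31800 nM.
Compound 2 `Cc1cc(C#N)cc(C)c1Oc1nc(Nc2ccc(C#N)cc2)ncc1-c1ccsc1`: compound 2 gives 3920 nM.
Compound 3 `Cc1cc(C#N)cc(C)c1Oc1nc(Nc2ccc(C#N)cc2)ncc1-c1cccnc1`: compound 3 gives 13500 nM.

Compound 3 holds the second highest number of the three: compound 1 sits nearest to it, and the step of a 2.4-fold lower number from compound 1 to compound 3 (0.37 log units; beyond the scatter) is beyond the scatter; compound 2 sits furthest, and the step of a 3.4-fold higher number from compound 2 to compound 3 (0.54 log units; beyond the scatter) is also beyond the scatter. The largest spread in the set is an 8.1-fold lower number from compound 1 to compound 2 (0.91 log units; beyond the scatter).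

Compound 4 `Cc1cc(C#N)cc(C)c1Oc1nc(Nc2ccc(C#N)cc2)ncc1-c1ccncc1` is the unmeasured member. It differs from compound 3 by pyridin-4-yl in place of pyridin-3-yl on an aromatic carbon. Among the compounds with values here, none of the measured steps moves a ring nitrogen within the same six-membered ring; the two steps touching compound 3 exchange the whole ring instead, and both are modest. A shift of the nitrogen alone, with the same atoms otherwise, is therefore expected to give a step no larger than the scatter in this assay, direction undetermined.

Compound 4 is estimated at 13500 nM in this assay, with a range of 5000 nM to 36000 nM, which is expected to mean a step of no change at the digits printed from compound 3 to compound 4 (within the scatter).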

Compound 4, half-maximal cytotoxic concentration: 28000 nM
The estimate for compound 4 lay 2.1-fold (0.32 log units) below the measured number, within the range that was stated.
By their numbers in this assay, from the lowest: compound 2; then compound 3; then compounds 4 and 1 (each within the scatter of the next).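

In this assay, moving the ring nitrogen alone, with the same atoms otherwise, gives a step beyond the scatter, a 2.1-fold higher number from compound 3 to compound 4 (0.32 log units; beyond the scatter), so pyridin-3-yl and pyridin-4-yl are not interchangeable at this position para to the (4-cyanophenyl)amino group. Pyridin-4-yl is the first replacement for phenyl here that stays within the scatter, with a 1.1-fold lower number from compound 1 to compound 4 (0.06 log units; within the scatter), while its step from the thiophen-3-yl compound remains clear, with a 7.1-fold higher number from compound 2 to compound 4 (0.85 log units; beyond the scatter) as the comparison. No measurement at hand accounts for these steps.

Going by these compounds, how pyridin-2-yl would read at this position remains open, and it would complete the set of ring nitrogen placements. Also open, on these data alone, is how a ring carrying an aminomethyl group or a carboxylic acid, or a morpholine in place of the aromatic ring, would read in this assay.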